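Swapping methyl for phenyl on two related cores

A few compounds are considered here, and "the series" means these few. Any claim that something is new, unique, unknown or untested is made for them only; others in the source may bear on it.

Measured compounds:
Compound 1, `CC(=O)NC(=S)Nc1ccncc1`, gives 2070 nM in an assay for inhibition of epoxide hydrolase 1 (Homo sapiens), read by fluorescence, using microsomes; a lower number here means a stronger inhibitor, a higher number a weaker inhibitor.
Compound 2, `O=C(NC(=S)Nc1ccncc1)c1ccccc1`, gives 2280 nM in this assay.
Compound 3, `CC(=O)NC(=S)Nc1ccc(Br)c2ccccc12`, gives 2420 nM in this assay.

Compound 1 and compound 2 differ in one place: phenyl in place of methyl on a carbonyl carbon. That change gave a 1.1-fold higher number from compound 1 to compound 2 (0.04 log units; within the scatter), so the two values cannot be told apart. Compound 3 carries a different core; the difference between the two cores is not broken down here. Its value sits close to those of compound 1 and compound 2, within the usual scatter of both.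

Compound 4, `O=C(NC(=S)Nc1ccc(Br)c2ccccc12)c1ccccc1`, has not yet been measured. It differs from compound 3 in the same way that compound 2 differs from compound 1: phenyl in place of methyl on a carbonyl carbon. The place is described in the same words for both pairs, so this is the same change, only made on the other core.

Because the earlier change gave a 1.1-fold higher number from compound 1 to compound 2 (0.04 log units; within the scatter), the step from compound 3 to compound 4 is expected to be small as well, roughly a 1.1-fold higher number from compound 3 to compound 4 (0.03 log units; within the scatter). Compound 4 is therefore expected to give about 2600 nM in this assay, most likely between 1200 nM and 5600 nM.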

Compound 4, half-maximal inhibitory concentration: 1880 nM
For compound 4 the middle estimate is 1.4-fold (0.14 log units) above the measured one; the range from low to high includes it.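

In this assay, putting phenyl in place of methyl on a carbonyl carbon of the core of compound 3 gave a 1.3-fold lower number from compound 3 to compound 4 (0.11 log units; within the scatter), so this step is too small to tell the two compounds apart. Set beside the same change on the core of compound 1, the two steps agree as far as these numbers can tell: the same change on two cores in this assay, a 1.1-fold higher number (0.04 log units; within the scatter) from compound 1 to compound 2 and a 1.3-fold lower number (0.11 log units; within the scatter) from compound 3 to compound 4, 1.4-fold (0.15 log units) apart, within the scatter of two such steps. This shows that on both cores the swap left the number within the scatter, so the change carries over between these two cores as one with no measurable effect; it does not show that the same would hold on any other core, and with neither step clear of the scatter, it cannot show a real effect shared by the two cores.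

The compounds shown leave open whether a different group on that carbonyl carbon, such as an amine or a longer chain, would move the number beyond the scatter. They also do not break down the difference between the two cores into its parts.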